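Aryl versus benzyl on the oxadiazole: a step toward compound 4

A few compounds are considered here, and "the series" means these few. Any claim that something is new, unique, unknown or untested is made for them only; others in the source may bear on it.

Measured so far:
compound 1 `FC(F)(F)c1cnc2c(c1)Oc1ccccc1C1=NCCN12` — > 100000 nM
compound 2 `c1ccc(OCc2noc(-c3ccc(C4=NCCN4)cc3)n2)cc1` — 9980 nM
compound 3 `Clc1cccc(-c2noc(-c3ccc(C4=NCCN4)cc3)n2)c1` — 64 nM

Of the compounds shown here, three have been tested in an assay for inhibition of Amine oxidase [flavin-containing] B (Homo sapiens), read by fluorescence and spectrophotometry, using microsomes, with stated times of 30 min and 20 min; on this read-out lower numbers stand for stronger inhibition and higher numbers for weaker inhibition. Compound 1 `FC(F)(F)c1cnc2c(c1)Oc1ccccc1C1=NCCN12` reaches only a limit of the assay, > 100000 nM. Compound 2 `c1ccc(OCc2noc(-c3ccc(C4=NCCN4)cc3)n2)cc1` gives 9980 nM in this assay. Going by the values given here, compound 3 `Clc1cccc(-c2noc(-c3ccc(C4=NCCN4)cc3)n2)c1` gives 64 nM, the lowest of the two numbers given, and the single measured step between them is a 160-fold lower number from compound 2 to compound 3 (2.19 log units; beyond the scatter).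

Compound 4 `Cc1ccc(Cc2noc(-c3ccc(C4=NCCN4)cc3)n2)cc1` has not yet been measured in this assay. It differs from compound 3 by 4-methylbenzyl in place of 3-chlorophenyl on an aromatic carbon. Among the compounds with values here, only the step from compound 2 to compound 3 bears on this change, and it was large: a group joined to the five-membered ring through a methylene carbon gave a far higher number than an aryl ring bound directly. Compound 4 again carries a methylene between that ring and its aryl group, though the group is a 4-methylbenzyl and not a phenoxymethyl, so the direction is expected to be upward and the size uncertain. For compound 4 the estimate in this assay is 1500 nM, within 200 nM to 12000 nM, which is expected to mean a step of a 23-fold higher number from compound 3 to compound 4 (1.37 log units; beyond the scatter).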

Compound 4, half-maximal inhibitory concentration: 3640 nM
Compound 4: middle estimate off by 2.4-fold (0.39 log units), on the low side; measured number inside the range.
By their numbers in this assay, from the lowest: compound 3; then compound 4; then compound 2. At a limit, above all of these: compound 1.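

With 4-methylbenzyl in place of 3-chlorophenyl on the aromatic carbon of the five-membered ring, the result is a 57-fold higher number from compound 3 to compound 4 (1.75 log units; beyond the scatter), so the high number of compound 2 is not confined to its phenoxymethyl group: compound 2 and compound 4 both carry a group joined through a saturated chain carbon, and both lie well above compound 3, whose aryl ring is bound directly. Between these two chain-linked compounds the change counts for much less, as 4-methylphenyl in place of phenoxy on the saturated chain carbon gives a 2.7-fold lower number from compound 2 to compound 4 (0.44 log units; beyond the scatter), a modest step though still beyond the scatter. Nothing among the data given here accounts for either step.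

As far as these compounds go, the step to compound 4 changes the link and the substituent on the aryl ring together, so the share of the methylene alone remains open, and a 3-chlorobenzyl group would be needed to separate the two. Also open, from the compounds shown here alone, is how a longer chain, or an amine on the aryl ring of compound 3, would read.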